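From cyano to hydrogen on an aromatic carbon

A few compounds are considered here, and "the series" means these few. Any claim that something is new, unique, unknown or untested is made for them only; others in the source may bear on it.

In an ADME assay on MT4 cells (Homo sapiens) for cytotoxicity (a lower number here means that less compound is tolerated, a higher number that more compound is tolerated), compound 2 `N#Cc1ccc(NC(=S)Nc2cccc(C(F)(F)F)c2)cc1` gives 7000 nM and compound 1 `FC(F)(F)c1cccc(NC(=S)Nc2ccc(I)cc2)c1` gives 10000 nM. Compound 2 has the lower of only these two numbers, but the gap is small: a 1.4-fold lower number from compound 1 to compound 2 (0.15 log units; within the scatter). Compound 3 `FC(F)(F)c1cccc(NC(=S)Nc2ccccc2)c1` differs from compound 2 by hydrogen in place of cyano on an aromatic carbon, with hydrogen in place of cyano on an aromatic carbon, para to a large group. One measured step bears on this change, the swap of iodo for cyano between compound 1 and compound 2, shown above as lying within the scatter. For the measured compounds named here, no measured compound yet carries hydrogen at that carbon, so this evidence is thin. Even so, no step beyond the scatter is expected in this assay. The estimated step is a 1.4-fold higher number from compound 2 to compound 3 (0.15 log units; within the scatter). Compound 3 is expected to give about 10000 nM, within an estimated range of 4000 nM to 30000 nM.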

Compound 3, half-maximal cytotoxic concentration: 39000 nM
Compound 3: middle estimate off by 3.9-fold (0.59 log units), on the low side; the whole stated range lies below it.
By their numbers in this assay, from the lowest: compounds 2 and 1 (each within the scatter of the next); then compound 3.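

In this assay this aromatic carbon proves more sensitive than the earlier pair suggested, since the swap between iodo and cyano alone had stayed within the scatter. Hydrogen in place of cyano brings a 5.6-fold higher number from compound 2 to compound 3 (0.75 log units; beyond the scatter) and hydrogen in place of iodo brings a 3.9-fold higher number from compound 1 to compound 3 (0.59 log units; beyond the scatter) at this same carbon, so among these three compounds the one without a substituent there stands apart, while the two carrying a substituent do not separate. Nothing available here explains why hydrogen differs from both groups.

Going by these compounds, whether another group at this carbon, such as an amine, a methoxy group or a carboxylic acid, would fall with cyano and iodo or with hydrogen remains open. Also open, on these data alone, is whether the same gain with hydrogen would hold if the trifluoromethyl group shared by all three compounds were replaced.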